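Moving from 2,6-dimethylphenyl to 3,5-dimethylphenyl

A few compounds are considered here, and "the series" means these few. Any claim that something is new, unique, unknown or untested is made for them only; others in the source may bear on it.

The compounds share one core and differ in the aromatic group on the chain. In a functional assay on HUVEC cells (Homo sapiens) for cytotoxicity (a higher number here means that more compound is needed for the effect, a lower number that less compound is needed), compound 1 `COC1=C(C)C(=O)/C(=C(O)/C=C/c2ccc(OC)cc2)C(=O)C1(C)C` gives 2.5 ug/mL, compound 2 `COC1=C(C)C(=O)/C(=C(O)/C=C/c2ccc(F)cc2)C(=O)C1(C)C` gives 2 ug/mL and compound 3 `COC1=C(C)C(=O)/C(=C(O)/C=C/c2c(C)cccc2C)C(=O)C1(C)C` gives 3 ug/mL. All three values lie within the scatter of one another, so compound 3 is not set apart from the other two.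

Compound 4 `COC1=C(C)C(=O)/C(=C(O)/C=C/c2cc(C)cc(C)c2)C(=O)C1(C)C` carries 3,5-dimethylphenyl in place of 2,6-dimethylphenyl on a double-bonded chain carbon bound to a double-bonded chain carbon. For the measured compounds named here, no measured step makes this exact exchange. The nearest evidence is the set of steps that change the same aromatic group: a 1.3-fold lower number from compound 1 to compound 2 (0.10 log units; within the scatter), a 1.2-fold higher number from compound 1 to compound 3 (0.08 log units; within the scatter) and a 1.5-fold higher number from compound 2 to compound 3 (0.18 log units; within the scatter). Each lies within the scatter, so no change beyond the scatter is expected in this assay. The expected step is a 1.2-fold lower number from compound 3 to compound 4 (0.08 log units; within the scatter), which is small and has no firm direction. Compound 4 is estimated at 2.5 ug/mL, with an expected range of 1.2 ug/mL to 5 ug/mL.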

Compound 4, concentration for half-maximal effect: 2.5 ug/mL
Compound 4: middle estimate and measured number agree at the digits printed; low and high end bracket the measured number.
By their numbers in this assay, from the lowest: compounds 2, 1, 4 and 3 (each within the scatter of the next).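

In this assay, for the compounds shown here, 3,5-dimethylphenyl in place of 2,6-dimethylphenyl gives a 1.2-fold lower number from compound 3 to compound 4 (0.08 log units; within the scatter), the first step that rearranges the same atoms instead of exchanging them for others. The new group is also not separated from the two other aromatic groups, with a 1.3-fold higher number from compound 2 to compound 4 (0.10 log units; within the scatter) and no change at the digits printed from compound 1 to compound 4 (within the scatter), so all four groups on this double-bonded chain carbon remain unresolved in this assay. No available data explain this flat result.

Still open, going by these compounds, is whether an amine or a carboxylic acid on the aromatic ring, or a pyridine in place of the phenyl, would produce a step beyond the scatter. Also open, on these data alone, is whether any change to the shared core would move the number.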